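The source may report more compounds than this note shows. Statements on the series, on what has been measured and on what is new or still open speak of the compounds shown alone.

Working notes on the series. The shared core is carried unchanged by compound 1 `CCC(=O)NC[C@H]1CN(c2ccc(-n3cc(-c4ccccn4)cn3)c(F)c2)C(=O)O1`, compound 2 `CS(=O)(=O)NC[C@H]1CN(c2ccc(-n3cc(-c4ccccn4)cn3)c(F)c2)C(=O)O1` and compound 3 `CN(C)S(=O)(=O)NC[C@H]1CN(c2ccc(-n3cc(-c4ccccn4)cn3)c(F)c2)C(=O)O1`; the three differ only in the group on the amine nitrogen of the side chain. In an ADME assay on HEK293-A cells (Homo sapiens) for cytotoxicity, read by MTT assay, with a stated time of 48 h (on this read-out higher numbers stand for weaker inhibition and lower numbers for stronger inhibition), compound 1 gives 389 ug/mL, compound 2 gives 314 ug/mL and compound 3 gives 249 ug/mL. The steps among them are a 1.2-fold lower number from compound 1 to compound 2 (0.09 log units; within the scatter), a 1.6-fold lower number from compound 1 to compound 3 (0.19 log units; within the scatter) and a 1.3-fold lower number from compound 2 to compound 3 (0.10 log units; within the scatter); compound 3 therefore stands within the scatter of both other compounds, and none of the three can be set apart from the others on these numbers.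

Compound 4 `COC(=O)NC[C@H]1CN(c2ccc(-n3cc(-c4ccccn4)cn3)c(F)c2)C(=O)O1` is not yet measured. The change from compound 3 is methoxycarbonyl in place of dimethylsulfamoyl on an amine nitrogen. The three measured steps are the only ones that bear on it, and each exchanged the group on this same amine nitrogen without moving the number beyond the scatter. For compound 4 the expected step is therefore a 1.2-fold higher number from compound 3 to compound 4 (0.08 log units; within the scatter), with no direction beyond the scatter. Compound 4 is estimated at 300 ug/mL in this assay, within a range of 150 ug/mL to 600 ug/mL.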

Compound 4, half-maximal inhibitory concentration: 306 ug/mL
Estimate against measurement, compound 4: 1.0-fold (0.01 log units) below; the range from low to high includes it.
By their numbers in this assay, from the lowest: compounds 3, 4, 2 and 1 (each within the scatter of the next).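

Methoxycarbonyl on the amine nitrogen stays within the scatter of both sulfonyl-bearing compounds in this assay (a 1.2-fold higher number from compound 3 to compound 4 (0.09 log units; within the scatter) and a 1.0-fold lower number from compound 2 to compound 4 (0.01 log units; within the scatter)), so the exchange between a carbonyl and a sulfonyl attachment, already seen within the scatter for propanoyl, also holds for this second carbonyl group. The step within the carbonyl groups, methoxy in place of ethyl on the carbonyl carbon, is also within the scatter (a 1.3-fold lower number from compound 1 to compound 4 (0.10 log units; within the scatter)), and the four groups on this nitrogen cannot be set apart on these numbers. Nothing at hand explains why these exchanges leave the number within the scatter.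

The compounds shown leave open whether a free amine or a carboxylic acid on the side chain would move the number beyond the scatter. Going by these compounds, a longer chain on the carbonyl carbon also remains untested here, as does any change to the shared core.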